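The compounds below may be only part of what the source reports. "The series", "measured", "known", "first", "only" and "open" are said of these compounds alone.

Values measured in an ADME assay on ET cells for cytotoxicity; on this read-out higher numbers stand for weaker inhibition and lower numbers for stronger inhibition:
- Compound 1 `Nc1ncnc2c1c(Cl)cn2[C@@H]1C=C(CO)[C@@H](O)[C@H]1O`: 50100 nM
- Compound 2 `Nc1ncnc2c1c(Br)cn2[C@@H]1C=C(CO)[C@@H](O)[C@H]1O`: 41700 nM

In this assay, among the measured compounds shown here, compound 2 gives 41700 nM, which lies within the scatter of the only other number available, that of compound 1. Compound 3 `Nc1ncnc2c1c(I)cn2[C@@H]1C=C(CO)[C@@H](O)[C@H]1O` has not yet been measured. Its structure departs from that of compound 2 at one place, with iodo in place of bromo on an aromatic carbon. For the measured compounds named here, one measured step bears on this change, the exchange of chloro for bromo at the same carbon, which gave a 1.2-fold lower number from compound 1 to compound 2 (0.08 log units; within the scatter). That single small step offers no reason to expect a change beyond the scatter, though it cannot show how iodo will behave. The expected step is a 1.2-fold lower number from compound 2 to compound 3 (0.08 log units; within the scatter). For compound 3 the estimated value is 35000 nM, with an expected range from 15000 nM to 70000 nM.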

Compound 3, half-maximal inhibitory concentration: 15000 nM
The estimate for compound 3 lay 2.3-fold (0.37 log units) above the measured number, and the stated range covers the measured number.
By their numbers in this assay, from the lowest: compound 3; then compounds 2 and 1 (each within the scatter of the next).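

In this assay this aromatic carbon no longer looks indifferent to which halogen it carries: iodo in place of bromo brings a 2.8-fold lower number from compound 2 to compound 3 (0.44 log units; beyond the scatter), whereas the earlier exchange of chloro for bromo had stayed within the scatter. Iodo in place of chloro brings a 3.3-fold lower number from compound 1 to compound 3 (0.52 log units; beyond the scatter), so iodo separates from both other halogens, while compound 1 and compound 2 cannot be told apart, and the change at this position proves modest but readable. The data give no account of why iodo stands apart from bromo and chloro.

As far as these compounds go, whether the lower number is special to iodo or extends to other groups at this carbon, such as a nitrile, a methyl or an ethynyl group, stays open. Also open is how fluoro would compare with the three halogens shown.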